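The compounds below may be only part of what the source reports. "The series", "measured", "known", "first", "only" and "open" are said of these compounds alone.

In an assay on HEK293 cells for antagonist activity at transient receptor potential M8 protein (Canis lupus familiaris), read by fluorescence and calcium flux, with a stated time of 5 min (a lower number here means a stronger inhibitor, a higher number a weaker inhibitor), compound 1 `O=C(C(Nc1ccccc1F)c1ccc(C(F)(F)F)cc1)N1CCCC1c1ccccc1F` gives 7 nM. Compound 2 `O=C(C(Nc1ccccc1F)c1ccc(C(F)(F)F)cc1)N1CCCC1c1ccccc1Cl`, with chloro in place of fluoro on an aromatic carbon, gives 11 nM in this assay, and compound 3 `COc1ccccc1C1CCCN1C(=O)C(Nc1ccccc1F)c1ccc(C(F)(F)F)cc1`, with methoxy in place of fluoro on an aromatic carbon, gives 12 nM in this assay. Of the three numbers, that of compound 3 is the largest, but both steps toward it are small, a 1.7-fold higher number from compound 1 to compound 3 (0.23 log units; within the scatter) and a 1.1-fold higher number from compound 2 to compound 3 (0.04 log units; within the scatter), so no order among the three compounds can be claimed.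

Compound 4 `O=C(C(Nc1ccccc1F)c1ccc(C(F)(F)F)cc1)N1CCCC1c1ccccn1` has not been measured. It differs from compound 3 by pyridin-2-yl in place of 2-methoxyphenyl on a saturated ring carbon. The measured steps that bear on this change are the exchanges of the substituent on that aromatic ring: a 1.6-fold higher number from compound 1 to compound 2 (0.20 log units; within the scatter), a 1.7-fold higher number from compound 1 to compound 3 (0.23 log units; within the scatter) and a 1.1-fold higher number from compound 2 to compound 3 (0.04 log units; within the scatter), each within the scatter. None of these replaces the ring itself, so the step to compound 4 rests on weaker ground. Because compound 1 gave 7 nM, compound 2 gave 11 nM and compound 3 gave 12 nM as the three measured variants at this position, compound 4 is expected to remain in a similar range, with a modest upward drift allowed for, an estimated step of a 1.7-fold higher number from compound 3 to compound 4 (0.22 log units; within the scatter). Compound 4 is therefore estimated at 20 nM in this assay, with a range from 6 nM to 70 nM.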

Compound 4, half-maximal inhibitory concentration: 25 nM
Estimate against measurement, compound 4: 1.3-fold (0.10 log units) below; the range from low to high includes it.
By their numbers in this assay, from the lowest: compounds 1, 2 and 3 (each within the scatter of the next); then compound 4.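

For the compounds shown here, exchanging the aromatic ring itself on the saturated ring carbon, and not just its substituent, is the first change at this position to move the number beyond the scatter in this assay. Pyridin-2-yl in place of 2-methoxyphenyl gives a 2.1-fold higher number from compound 3 to compound 4 (0.32 log units; beyond the scatter) and in place of 2-chlorophenyl gives a 2.3-fold higher number from compound 2 to compound 4 (0.36 log units; beyond the scatter), while in place of 2-fluorophenyl it gives a 3.6-fold higher number from compound 1 to compound 4 (0.55 log units; beyond the scatter) as the largest of the three steps. The three substituted phenyl compounds could not be ordered among themselves, but compound 4 stands apart from all of them as the weakest inhibitor of the four, although each step is only modest, and no measurement at hand offers a reason for this shift.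

The compounds shown leave open whether the step goes with the nitrogen of the pyridin-2-yl group or with the lack of any substituent on that ring, as compound 4 differs from the other three in both respects. A plain phenyl group on this carbon would separate the two readings, and the same question stands for pyridin-3-yl, pyridin-4-yl, or a pyridin-2-yl group carrying a fluoro or methoxy substituent.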